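Swapping an Ester Tail for a Piperazinylethyl Urea

The source may hold more compounds than are shown below. What is called first, only, known or untested is meant among the compounds shown, and "the series" means these compounds.

Compound 3 `CCOC(=O)CNc1nc2ccc(-c3cnc(OC)c(NS(=O)(=O)c4ccc(F)cc4)c3)cc2s1` carries an (ethoxycarbonyl)methyl group on a nitrogen on an aromatic ring, and in a functional assay on A549 cells (Homo sapiens) for antiproliferative activity, read by MTT assay, with a stated time of 72 h (a lower number here means a stronger inhibitor, a higher number a weaker inhibitor), compound 3 gives "not determined" (no result reported), so it stands nowhere on the numbers. Compound 4 `COc1ncc(-c2ccc3nc(NC(=O)NCCN4CCN(C)CC4)sc3c2)cc1NS(=O)(=O)c1ccc(F)cc1` differs from it in one place: (2-(4-methylpiperazin-1-yl)ethyl)carbamoyl in place of (ethoxycarbonyl)methyl on a nitrogen on an aromatic ring. Within the data shown here, the only step that bears on this change is the one between compound 1 `COc1ncc(-c2ccc3nc(NC(=O)NCCN(C)C)sc3c2)cc1NS(=O)(=O)c1ccc(F)cc1`, which in this assay gives 470 nM, and compound 2 `COc1ncc(-c2ccc3nc(NC(=O)NC4CC4)sc3c2)cc1NS(=O)(=O)c1ccc(F)cc1`, which in this assay gives 900 nM: a 1.9-fold higher number from compound 1 to compound 2 (0.28 log units; within the scatter). Compound 4 shares the urea of both and its 2-(4-methylpiperazin-1-yl)ethyl group resembles that of compound 1, so a result near 470 nM is expected, with no step beyond the scatter in either direction. For compound 4 the estimate is 500 nM, between 150 nM and 1600 nM.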

Compound 4, half-maximal inhibitory concentration: 550 nM
Compound 4: the middle estimate sits 1.1-fold (0.04 log units) below what was measured; low and high end bracket the measured number.
By their numbers in this assay, from the lowest: compounds 1, 4 and 2 (each within the scatter of the next).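

Compound 4 widens the picture: a 1.2-fold higher number from compound 1 to compound 4 (0.07 log units; within the scatter) comes with 4-methylpiperazin-1-yl in place of dimethylamino, and a 1.6-fold lower number from compound 2 to compound 4 (0.21 log units; within the scatter) comes with 2-(4-methylpiperazin-1-yl)ethyl in place of cyclopropyl, both in this assay. On this urea nitrogen, a group carrying a six-membered non-aromatic ring thus gives a result within the scatter of both the dimethylamino chain and the cyclopropyl. No measurement at hand accounts for this result. The compounds shown leave open whether a carboxylic acid, a morpholine or a longer chain here would stay within the scatter too. Compound 3, with no number, says nothing on whether the urea itself matters.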